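Configuration change from compound 3 to compound 4

The source may report more compounds than this note shows. Statements on the series, on what has been measured and on what is new or still open speak of the compounds shown alone.

In a functional assay on PC-3 cells (Homo sapiens) for antiproliferative activity, read by MTT assay, with a stated time of 24 h (a higher number here means a weaker inhibitor, a lower number a stronger inhibitor), compound 1 (`CCn1c(C(=O)N[C@H](C)C(=O)OC)ccc1C(CC)(CC)c1ccc(OCS(=O)(=O)c2ccccc2)c(C)c1`) reaches only a limit, > 50000 nM. Compound 2 (`CCn1c(C(=O)N[C@@H](CC(=O)OC)C(=O)OC)ccc1C(CC)(CC)c1ccc(OCS(=O)(=O)c2ccccc2)c(C)c1`) gives 6490 nM, and compound 3 (`CCn1c(C(=O)N[C@H](CO)CCCO)ccc1C(CC)(CC)c1ccc(OCS(=O)(=O)c2ccccc2)c(C)c1`) gives 6810 nM. Compound 3 therefore stands level with compound 2, with a 1.0-fold higher number from compound 2 to compound 3 (0.02 log units; within the scatter). Both differ clearly from compound 1, with an at least 7.7-fold lower number from compound 1 to compound 2 (0.88 log units; beyond the scatter) and an at least 7.3-fold lower number from compound 1 to compound 3 (0.86 log units; beyond the scatter).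

Compound 4 (`CCn1c(C(=O)N[C@@H](CO)CCCO)ccc1C(CC)(CC)c1ccc(OCS(=O)(=O)c2ccccc2)c(C)c1`) keeps the same atoms and bonds: the two compounds have the same atoms and bonds and differ only in configuration as drawn: 1 of 1 stereo elements differ; a stereocentre at a saturated chain carbon is drawn S in compound 3 and R in compound 4. All three measured steps replace the group on the amide-type nitrogen, and none isolates configuration, so they bear only indirectly. Their size, up to an at least 7.7-fold lower number from compound 1 to compound 2 (0.88 log units; beyond the scatter), keeps the range wide. The expected step is a 1.0-fold higher number from compound 3 to compound 4 (0.01 log units; within the scatter), with no change beyond the scatter anticipated. For compound 4 the estimated value is 7000 nM, with an expected range of 2500 nM to 25000 nM.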

Compound 4, half-maximal inhibitory concentration: 13400 nM
Compound 4: middle estimate off by 1.9-fold (0.28 log units), on the low side; the range from low to high includes it.
By their numbers in this assay, from the lowest: compounds 2, 3 and 4 (each within the scatter of the next, the first and the last beyond it). At a limit, above all of these: compound 1.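

In this assay, for the compounds shown here, the only pair differing solely in configuration gives a 2.0-fold higher number from compound 3 to compound 4 (0.29 log units; within the scatter), so the S and R drawings at this stereocentre are not separated beyond the scatter. Against compound 2, only the R form separates, with a 2.1-fold higher number from compound 2 to compound 4 (0.31 log units; beyond the scatter). Compound 1 is only a limit, so an at least 3.7-fold lower number from compound 1 to compound 4 (0.57 log units; beyond the scatter) is a bound and not a measured difference.

On these data alone, whether this configuration change behaves alike with the ester-bearing groups stays open. So does the outcome of an amine or carboxylic acid in place of either hydroxyl, or of a longer chain.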